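PAK4 series: cyclohexyl stereoisomer step from compound 3 to 4

The source may report more compounds than this note shows. Statements on the series, on what has been measured and on what is new or still open speak of the compounds shown alone.

Measured so far in an assay on isolated protein for inhibition of serine/threonine-protein kinase PAK 4 (Homo sapiens), read by filter binding, with a stated time of 20 min; on this read-out lower numbers stand for stronger inhibition and higher numbers for weaker inhibition:
- compound 1 `N[C@H]1CCCN(c2nc(Nc3cccc(Cl)c3)nc3[nH]ccc23)C1`: 229 nM
- compound 2 `N[C@@H]1CCCN(c2nc(Nc3cccc(Cl)c3)nc3[nH]ccc23)C1`: 229 nM
- compound 3 `N[C@H]1CC[C@@H](Nc2nc(Nc3cccc(Cl)c3)nc3[nH]ccc23)CC1`: 2.7 nM

Compound 3 gives the lowest number of the three; the step of an 85-fold lower number from compound 1 to compound 3 (1.93 log units; beyond the scatter) and the step of an 85-fold lower number from compound 2 to compound 3 (1.93 log units; beyond the scatter) are both beyond the scatter, so compound 3 stands clearly apart from compounds 1 and 2 on the numbers shown.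

Compound 4 `N[C@H]1CC[C@H](Nc2nc(Nc3cccc(Cl)c3)nc3[nH]ccc23)CC1` is the unmeasured partner of compound 3: the two compounds have the same atoms and bonds and differ only in configuration as drawn: 2 of 2 stereo elements differ (all stereocentres are inverted: mirror images); a stereocentre at a saturated ring carbon is drawn s in compound 3 and r in compound 4; a stereocentre at a saturated ring carbon is drawn s in compound 3 and r in compound 4. No other group leaves or enters; the (4-aminocyclohexyl)amino on the aromatic carbon is kept.

Among the measured compounds shown here, the one measured step of the same kind is no change at the digits printed from compound 1 to compound 2 (within the scatter), which is within the scatter because of the fact that compounds 1 and 2 differ only in the configuration as drawn. The large steps to compound 3 concern a different group and do not bear on a configuration change alone. On this basis the step of a 1.9-fold higher number from compound 3 to compound 4 (0.27 log units; within the scatter) is expected to be small, with no direction beyond the scatter claimed. Compound 4 is therefore estimated at 5 nM, within a range of 1.5 nM to 20 nM, an expectation that rests on a single measured pair.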

Compound 4, half-maximal inhibitory concentration: 20.2 nM
Compound 4: middle estimate off by 4.0-fold (0.61 log units), on the low side; the whole stated range lies below it.
By their numbers in this assay, from the lowest: compound 3; then compound 4; then compounds 1 and 2 (each within the scatter of the next).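

In this assay, a change of configuration alone now moves the number beyond the scatter, with a 7.5-fold higher number from compound 3 to compound 4 (0.87 log units; beyond the scatter), and this step can be put down to configuration because no atom or bond changes: the fact that compounds 3 and 4 differ only in the configuration as drawn

The 3-aminopiperidin-1-yl pair gave no such separation, with no change at the digits printed from compound 1 to compound 2 (within the scatter), so insensitivity to configuration does not carry over from that group to the (4-aminocyclohexyl)amino group. The gain from (4-aminocyclohexyl)amino in place of 3-aminopiperidin-1-yl does not rest on one configuration, as it remains beyond the scatter for the higher-numbered cyclohexyl isomer, with an 11-fold lower number from compound 1 to compound 4 (1.05 log units; beyond the scatter) and an 11-fold lower number from compound 2 to compound 4 (1.05 log units; beyond the scatter).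

The compounds shown leave open whether the configuration gap on the cyclohexyl ring persists when its primary amine is replaced by a hydroxyl, a dimethylamino group or a longer aminomethyl chain. Also open, going by these compounds, is whether the same gap holds with a nitrile in place of the chlorine.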